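The source may report more compounds than this note shows. Statements on the series, on what has been measured and on what is new or still open speak of the compounds shown alone.

Three compounds have been measured in a functional assay on HEK293 cells for antagonist activity at Voltage-dependent L-type calcium channel subunit alpha-1D (Rattus norvegicus), read by FLIPR; on this read-out higher numbers stand for weaker inhibition and lower numbers for stronger inhibition:

compound 1 `CCCCCOC(=O)C1=C(C)NC(C)=C(C(=O)OCC)C1c1cccc([N+](=O)[O-])c1`: 130 nM
compound 2 `C=C(C)C(=O)OCCOC(=O)C1=C(C)NC(C)=C(C(=O)OCC)C1c1cccc([N+](=O)[O-])c1`: 10 nM
compound 3 `COC(=O)C1=C(C)NC(C)=C(C(=O)OC2C=CCCC2)C1c1cccc([N+](=O)[O-])c1`: 10 nM

Compound 3 and compound 2 stand level at the digits shown, and together they hold the lowest numbers of the three; compound 1 gives a higher number than either, a gap beyond the scatter. For the measured compounds named here, the one step among the measured compounds is a 13-fold lower number from compound 1 to compound 2 (1.11 log units; beyond the scatter), which concerns a change on the ester group that sits on the other side of the shared core from the one now in question.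

The next compound, compound 4 `COC(=O)C1=C(C)NC(C)=C(C(=O)OCCCOc2ccccc2)C1c1cccc([N+](=O)[O-])c1`, differs from compound 3 by 3-phenoxypropyl in place of cyclohex-2-en-1-yl on an oxygen next to a carbonyl group. Going by the values given here, no measured step alters this ester group, so the only guide is the large step from compound 1 to compound 2, which changed a saturated chain on an ester oxygen and lowered the number. That step bears only loosely on the present change, so the expected step of a 1.5-fold higher number from compound 3 to compound 4 (0.18 log units; within the scatter) is small, with no direction beyond the scatter firmly expected. Compound 4 is estimated at 15 nM, within 4 nM to 60 nM.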

Compound 4, half-maximal inhibitory concentration: 11 nM
For compound 4 the middle estimate is 1.4-fold (0.13 log units) above the measured one; measured number inside the range.
By their numbers in this assay, from the lowest: compounds 2, 3 and 4 (each within the scatter of the next); then compound 1.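

In this assay, for the compounds shown here, 3-phenoxypropyl in place of cyclohex-2-en-1-yl on an oxygen next to a carbonyl group gives a 1.1-fold higher number from compound 3 to compound 4 (0.04 log units; within the scatter), the first measured change at this ester group. The two groups therefore read alike here, although the entering group has 10 heavy atoms against 6, an aromatic ring instead of a non-aromatic one and one hydrogen-bond acceptor against none. No supporting evidence is available to explain this result.

The compounds shown leave open whether the same level would hold with a chain ending in an amine or a carboxylic acid on this oxygen. They also do not separate the part played by the chain oxygen from that of the aromatic ring, a question that 3-phenylpropyl in place of 3-phenoxypropyl could address.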